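Thiophenyl for Methoxyphenyl on the Shared Core

A few compounds are considered here, and "the series" means these few. Any claim that something is new, unique, unknown or untested is made for them only; others in the source may bear on it.

Two members of the series have been tested so far. Compound 1 `CCOc1nc(-c2cc3ccccc3o2)cc(-c2ccc(Br)cc2)c1C#N` gives 227000 nM in a functional assay on aorta (strain Wistar) for inhibition, with Thoracic aorta (Rattus norvegicus) as the target (a lower number here means a stronger inhibitor, a higher number a weaker inhibitor), and compound 2 `CCOc1nc(-c2cc3ccccc3o2)cc(-c2ccc(OC)cc2)c1C#N` gives 204000 nM. Within the data shown here, the single step between them, a 1.1-fold lower number from compound 1 to compound 2 (0.05 log units; within the scatter), leaves the two numbers together. Compound 2 carries the smaller of the two numbers, yet with compound 1 within the scatter no separation between them can be read.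

Compound 3 `CCOc1nc(-c2cc3ccccc3o2)cc(-c2cccs2)c1C#N` differs from compound 2 by thiophen-2-yl in place of 4-methoxyphenyl on an aromatic carbon. Among the measured compounds shown here, no measured step concerns this exchange; the only step available, a 1.1-fold lower number from compound 1 to compound 2 (0.05 log units; within the scatter), alters a different part of the aryl group and stays within the scatter. It gives no ground for expecting movement beyond the scatter in this assay. Compound 3 is therefore expected close to its neighbour, with the step of a 1.1-fold higher number from compound 2 to compound 3 (0.03 log units; within the scatter) as the estimate. The expected value for compound 3 is 220000 nM, with a range of 100000 nM to 500000 nM.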

Compound 3, half-maximal inhibitory concentration: 308000 nM
The estimate for compound 3 lay 1.4-fold (0.15 log units) below the measured number, and the stated range covers the measured number.
By their numbers in this assay, from the lowest: compounds 2, 1 and 3 (each within the scatter of the next).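

In this assay thiophen-2-yl in place of 4-methoxyphenyl gives a 1.5-fold higher number from compound 2 to compound 3 (0.18 log units; within the scatter) and thiophen-2-yl in place of 4-bromophenyl gives a 1.4-fold higher number from compound 1 to compound 3 (0.13 log units; within the scatter) at the place opposite the ring nitrogen. The earlier step changed only the substituent on the phenyl ring, whereas these steps exchange the aromatic ring itself, a six-membered ring of carbon for a five-membered ring with sulfur, and still no separation appears among the three compounds. Nothing available bears on why the numbers stay together.

Open, as far as these compounds go, is whether any group at this position can give a step beyond the scatter, for example an amine or a carboxylic acid on the aromatic ring. Also open, from the compounds shown here alone, is whether the ethoxy group, or a longer chain in its place, matters more than this position.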